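The source may report more compounds than this note shows. Statements on the series, on what has been measured and on what is new or still open speak of the compounds shown alone.

Within the data shown here, in a functional assay on NCI-H460 cells (Homo sapiens) for inhibition, read by sulforhodamine B assay, with a stated time of 48 h, tested at 10 uM (a lower number here means less inhibition, a higher number more inhibition at the concentration tested (going by the name of the read-out)), compound 1 `c1ccc2c(-c3cn4ccnc4c(-c4ccc5ncn(C6CCCCC6)c5c4)n3)cccc2c1` gives 3.61%, the higher of the two numbers measured so far. Its nearest neighbour, compound 2 `c1csc(-c2cn3ccnc3c(-c3ccc4ncn(C5CCCCC5)c4c3)n2)c1`, gives 1.3%, and the step of a number 2.3 percentage points lower from compound 1 to compound 2 (within the scatter) shows that swapping the ring group at that position left the read-out essentially unchanged. Compound 3 `FC(F)(F)c1cccc(-c2cn3ccnc3c(-c3ccc4ncn(C5CCCCC5)c4c3)n2)c1` carries a different swap at the same position, (3-(trifluoromethyl)phenyl in place of naphthalen-1-yl on an aromatic carbon). Among the measured compounds shown here, only the step from compound 1 to compound 2 bears on this change, and it was within the scatter, so no step beyond the scatter is expected in a number 0.4 percentage points higher from compound 1 to compound 3 (within the scatter). Compound 3 is therefore estimated at 4%, between -6% and 14%.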

Compound 3, a percentage reported as inhibition, at one concentration (the size of the read-out at that concentration, not a potency): 4.38%
Compound 3: middle estimate off by 0.4 percentage points, on the low side, within the range that was stated.
By their numbers in this assay, from the lowest: compounds 2, 1 and 3 (each within the scatter of the next).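

A third kind of group at this position behaves like the first two: there is a number 0.8 percentage points higher from compound 1 to compound 3 (within the scatter) and a number 3.1 percentage points higher from compound 2 to compound 3 (within the scatter) in this assay for a single ring carrying trifluoromethyl. Two fused aromatic rings, thiophen-2-yl and 3-(trifluoromethyl)phenyl therefore cannot be told apart by this read-out. No supporting data bear on why this is so.

Going by these compounds, it remains open whether an amine or a carboxylic acid at this position would shift the read-out. On these data alone, whether changes elsewhere on the shared core would do so is also open.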